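Ring size on the sulfonyl: compound 2 to compound 3

A few compounds are considered here, and "the series" means these few. Any claim that something is new, unique, unknown or untested is made for them only; others in the source may bear on it.

Of the compounds shown here, two have been measured so far in an ADME assay on cells (Hepatocyte, Homo sapiens) for metabolic stability, read by LC-MS, tested at 1 uM (a higher number here means that the compound lasts longer, a lower number that the compound disappears faster), and both give similar readings. Compound 1 (`Cc1ccnc(NC(=O)c2ccsc2NC(=O)c2ccc(S(=O)(=O)N3CCCCC3)cc2)n1`) gives 0.39 h as its half-life. Compound 2 (`CCOC(=O)NC(=O)c1ccsc1NC(=O)c1ccc(S(=O)(=O)N2CCCC2)cc1`) gives 0.4 h and so stands level with compound 1 within the scatter. The two numbers therefore define one shared level and no ranking.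

Compound 3 (`CCOC(=O)NC(=O)c1ccsc1NC(=O)c1ccc(S(=O)(=O)N2CCCCC2)cc1`) has not yet been measured in this assay and departs from compound 2 at a single place. The change reads piperidin-1-yl in place of pyrrolidin-1-yl on a sulfonyl sulfur in the counted comparison, which is piperidin-1-yl in place of pyrrolidin-1-yl on a sulfonyl sulfur.

Within the data shown here, no measured pair differs at only one place, so no direct precedent exists for the size of this step. The expectation rests on compound 2 at 0.4 h and assumes little movement, with no firm direction. The expected step of a 1.1-fold lower number from compound 2 to compound 3 (0.03 log units; within the scatter) stays within the scatter. Compound 3 is estimated at 0.37 h with an expected range from 0.2 h to 0.65 h in this measurement.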

Compound 3, half-life: 0.498 h
Beside the measured number, compound 3's estimate is 1.3-fold (0.13 log units) below it; the range from low to high includes it.
By their numbers in this assay, from the lowest: compounds 1, 2 and 3 (each within the scatter of the next).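

In this assay, among these compounds, the first comparison at the sulfonyl sulfur, piperidin-1-yl in place of pyrrolidin-1-yl, gives a 1.2-fold higher number from compound 2 to compound 3 (0.10 log units; within the scatter) and so places the six-membered and five-membered rings on one level, with the extra ring carbon leaving the half-life inside the scatter. The second one-place pair concerns the amide-type nitrogen, where ethoxycarbonyl in place of 4-methylpyrimidin-2-yl gives a 1.3-fold higher number from compound 1 to compound 3 (0.11 log units; within the scatter) and so places these two quite different groups on one level as well, which holds for this pair with piperidin-1-yl on the sulfonyl sulfur and no further. Nothing available explains either reading.

From the compounds shown here alone, both pairs span only a narrow set of groups, so the sulfonyl position remains open for an azepan-1-yl ring, a morpholin-4-yl ring with its second hetero atom in the ring, or an open-chain dimethylamino group. Going by these compounds, the amide-type nitrogen remains equally open for a simple acetyl group or a longer alkoxycarbonyl chain, and whether any of these would lift the half-life clear of the shared level cannot be told from the three compounds in hand.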